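This account rests on a few compounds, and the source may have more. Where it says the series, first, only, none or still open, it means among the compounds named here.

Working notes on the series. In an ADME assay on MDBK cells (Bos taurus) for cytotoxicity, read by MTT assay, with a stated time of 96 h (on this read-out lower numbers stand for higher toxicity in this test and higher numbers for lower toxicity in this test), compound 1 `FC(F)(F)c1cccc(/N=N/N2CCCC2)c1` gives > 100000 nM, which is a limit of the assay and not a number. Compound 2 `CN(C)CCCN(/N=N/c1cc(F)ccc1F)c1ccccc1` gives 25000 nM in this assay. Going by the values given here, no pair of measured compounds differing in one place is available, so no measured step can be stated; compound 1 stands at the limit of > 100000 nM in this assay, at which 1 of the 2 values shown sits, and compound 2 shows a number, and of that pair only these two values can be reported. Compound 3 `c1ccc(/N=N/N2CCCC2)cc1` is not yet measured in this assay. Its difference from compound 1 is hydrogen in place of trifluoromethyl on an aromatic carbon. Among the compounds with values here, for this assay no step beyond the scatter is expected from compound 1 to compound 3, since compound 1 sits at the limit of > 100000 nM in this assay, at which 1 of the 2 values shown sits, and the series gives no measured step by which a change of this kind could be sized. Compound 3 is expected to give about 100000 nM, within 30000 nM to 300000 nM, and most probably to be reported again only as a limit. The expected step of a number no higher from compound 1 to compound 3 (the limit leaves the size open) is none beyond the scatter.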

Compound 3, half-maximal cytotoxic concentration: > 100000 nM
Compound 3: no number, only a limit; the forecaster's own chance of this, stated with the estimate: 70%; the middle value sits exactly at the limit.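

Compound 1 and compound 3 both give only a limit in this assay, so no step can be read for hydrogen in place of trifluoromethyl on an aromatic carbon: the limit of > 100000 nM in this assay, at which 2 of the 3 values shown sit.

The compounds shown leave open whether this change alters the half-maximal cytotoxic concentration at all, and what number either compound would give in this assay.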